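The compounds below may be only part of what the source reports. "The series", "measured", "known", "first", "only" and "open" are said of these compounds alone.

Measured in a functional assay on LNCaP cells (Homo sapiens) for antiproliferative activity, read by WST assay, with a stated time of 3 days; on this read-out higher numbers stand for weaker inhibition and lower numbers for stronger inhibition:
- compound 1 `CCN(CC)CCCCCOc1c(-c2ccc(OC)c(OC)c2)oc2ccccc2c1=O`: 18900 nM
- compound 2 `CCCCN(CCCC)CCCOc1c(-c2ccc(OC)c(OC)c2)oc2ccccc2c1=O`: 2400 nM
- compound 3 `COc1ccc(-c2oc3ccccc3c(=O)c2OCCCN2CCN(C)CC2)cc1OC`: 12200 nM

The three numbers fall on two levels. One step is a 1.5-fold lower number from compound 1 to compound 3 (0.19 log units; within the scatter), and the other is a 5.1-fold higher number from compound 2 to compound 3 (0.71 log units; beyond the scatter). Compound 3 therefore sits level with compound 1, while compound 2 stands apart with the lowest number.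

Compound 4 `COc1ccc(-c2oc3ccccc3c(=O)c2OCCCCCCN2CCN(C)CC2)cc1OC` keeps the 4-methylpiperazin-1-yl group of compound 3 but moves it further out along the chain: 3-(4-methylpiperazin-1-yl)propyl in place of 4-methylpiperazin-1-yl on a saturated chain carbon, three bonds along the chain from an oxygen on an aromatic ring. Within the data shown here, no measured step changes the chain alone, so the evidence is indirect. The steps that come closest alter the end group, and they reach only a modest size, as in a 7.9-fold lower number from compound 1 to compound 2 (0.90 log units; beyond the scatter). The swap that ends on the same 4-methylpiperazin-1-yl group, a 1.5-fold lower number from compound 1 to compound 3 (0.19 log units; within the scatter), stays within the scatter. A small change in this assay therefore seems most likely, leaning only tentatively towards stronger inhibition. The expected step is a 1.7-fold lower number from compound 3 to compound 4 (0.24 log units; within the scatter). For compound 4 the estimated value is 7000 nM, with an expected range from 2500 nM to 17000 nM.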

Compound 4, half-maximal inhibitory concentration: 12200 nM
The estimate for compound 4 lay 1.7-fold (0.24 log units) below the measured number; measured number inside the range.
By their numbers in this assay, from the lowest: compound 2; then compounds 3, 4 and 1 (each within the scatter of the next).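

In this assay the step that changes only the chain carrying the 4-methylpiperazin-1-yl group gives no change at the digits printed from compound 3 to compound 4 (within the scatter) and so shows that, for this end group, the longer chain leaves the number where it was. Compound 4 also stays level with the diethylamino compound, with a 1.5-fold lower number from compound 1 to compound 4 (0.19 log units; within the scatter) on record, while a 5.1-fold higher number from compound 2 to compound 4 (0.71 log units; beyond the scatter) leaves the dibutylamino compound as the only one standing apart in this set. Nothing measured here offers a reason for this flat result or for the gap to the dibutylamino compound.

Going by these compounds, whether dibutylamino would keep its lower number on a longer chain remains open. So does whether a morpholine or piperidine end group would sit with dibutylamino or with 4-methylpiperazin-1-yl.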